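Amide-to-ester swap at the pyrrole carbonyl of the series

The source may hold more compounds than are shown below. What is called first, only, known or untested is meant among the compounds shown, and "the series" means these compounds.

The series shares one core and differs only in the group on the carbonyl carbon attached to the aromatic carbon. In an assay on HL-60 cells for agonist activity at vitamin D3 receptor (Homo sapiens), read by microscopy, with a stated time of 96 h (on this read-out higher numbers stand for an effect only at larger amounts of compound and lower numbers for an effect already at smaller amounts), compound 1 `CCn1c(C(=O)NCCCN(C)C)ccc1C(CC)(CC)c1ccc(OCC(=O)C(C)(C)C)c(C)c1` gives 96 nM, compound 2 `CCn1c(C(=O)NCCN)ccc1C(CC)(CC)c1ccc(OCC(=O)C(C)(C)C)c(C)c1` gives 120 nM, and compound 3 `CCn1c(C(=O)N(C)CCC#N)ccc1C(CC)(CC)c1ccc(OCC(=O)C(C)(C)C)c(C)c1` gives 9800 nM. Compound 3 stands at the highest of the three numbers: the nearest is compound 2, with an 82-fold higher number from compound 2 to compound 3 (1.91 log units; beyond the scatter), and the furthest is compound 1, with a 100-fold higher number from compound 1 to compound 3 (2.01 log units; beyond the scatter). Between compound 1 and compound 2 the change is a 1.3-fold higher number from compound 1 to compound 2 (0.10 log units; within the scatter).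

Compound 4 `C#CC(C)OC(=O)c1ccc(C(CC)(CC)c2ccc(OCC(=O)C(C)(C)C)c(C)c2)n1CC` is not yet measured. It differs from compound 3 by (1-methylprop-2-yn-1-yl)oxy in place of (2-cyanoethyl)(methyl)amino on a carbonyl carbon. For the measured compounds named here, no measured step replaces an amide-type group with an ester, so nothing bears on this change directly. The two steps that bear on it loosely, a 100-fold higher number from compound 1 to compound 3 (2.01 log units; beyond the scatter) and an 82-fold higher number from compound 2 to compound 3 (1.91 log units; beyond the scatter), show that removing the chain-borne amino group from the carbonyl substituent carried a large rise in this assay; compound 4, like compound 3, holds no such group, so a number in the neighbourhood of compound 3 is expected, with a wide range in both directions. The expected step is a 1.0-fold higher number from compound 3 to compound 4 (0.01 log units; within the scatter). For compound 4 the estimate in this assay is 10000 nM, spanning 2000 nM to 50000 nM.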

Compound 4, half-maximal effective concentration: 210 nM
Compound 4: middle estimate off by 48-fold (1.68 log units), on the high side, and the stated range ends above it.
By their numbers in this assay, from the lowest: compounds 1, 2 and 4 (each within the scatter of the next, the first and the last beyond it); then compound 3.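

In this assay, (1-methylprop-2-yn-1-yl)oxy on the carbonyl carbon gives a 47-fold lower number from compound 3 to compound 4 (1.67 log units; beyond the scatter) so the high number of compound 3 does not follow simply from the lack of a chain-borne amino group, which compound 4 also lacks. Against the two amides that carry such a group, the ester shows a 1.8-fold higher number from compound 2 to compound 4 (0.24 log units; within the scatter) and a 2.2-fold higher number from compound 1 to compound 4 (0.34 log units; beyond the scatter) with the first within the scatter and the second a modest step beyond it, so in compound 4 a number close to those of compound 1 and compound 2 is reached without any amino group on the carbonyl substituent. Nothing measured on these compounds explains the gap between compound 3 and compound 4, and no cause can be assigned to it.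

Going by these compounds, it remains open whether the ester oxygen or the 1-methylprop-2-yn-1-yl chain matters more here, a question that a methyl ester, an isopropyl ester or a secondary amide bearing the same alkynyl chain would address. On these data alone, it is equally open whether the nitrogen methyl or the nitrile goes with the high number of compound 3, which the secondary 2-cyanoethyl amide would help to separate.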